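Halogen pattern on the sulfonyl phenyl and EP1 binding

This account rests on a few compounds, and the source may have more. Where it says the series, first, only, none or still open, it means among the compounds named here.

Measured so far in an assay on isolated protein with prostaglandin E2 receptor EP1 subtype (Homo sapiens) as the target, read by FLIPR, tested at 1 uM; on this read-out higher numbers stand for a stronger effect at the one concentration tested and lower numbers for a weaker effect:
- compound 1 `Cc1cn(Cc2ccc(Cl)cc2Cl)c2c(-c3nnc(NS(=O)(=O)c4cc(F)c(F)cc4F)o3)cc(F)cc12` gives 94%
- compound 2 `Cc1cn(Cc2ccc(Cl)cc2Cl)c2c(-c3nnc(NS(=O)(=O)c4ccc(Cl)c(Cl)c4)o3)cc(F)cc12` gives 16%

Compound 2 stands lowest of the two numbers; its nearest neighbour is compound 1. Within the data shown here, the one step measured, a number 78 percentage points lower from compound 1 to compound 2 (beyond the scatter), is large and runs downward, and it is the only step that bears on what follows.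

Compound 3 `Cc1cn(Cc2ccc(Cl)cc2Cl)c2c(-c3nnc(NS(=O)(=O)c4ccc(F)c(F)c4)o3)cc(F)cc12` has not yet been measured. It differs from compound 2 in one place: 3,4-difluorophenyl in place of 3,4-dichlorophenyl on a sulfonyl sulfur. The group that leaves here is the same 3,4-dichlorophenyl that entered in the measured step, and the group that enters carries fluorine, as did the 2,4,5-trifluorophenyl of compound 1. Among the measured compounds shown here, on that single comparison, an upward step is expected from compound 2 to compound 3, though of uncertain size, since the fluorine pattern of compound 3 is not the one of compound 1; the expected step is a number 44 percentage points higher from compound 2 to compound 3 (beyond the scatter). Compound 3 is therefore estimated at 60%, with a range from 25% to 90%.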

Compound 3, a percentage reported as activity, at one concentration (the size of the read-out at that concentration, not a potency): 30%
For compound 3 the middle estimate is 30 percentage points above the measured one; measured number inside the range.
By their numbers in this assay, from the lowest: compound 2; then compound 3; then compound 1.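

In this assay, the read-out moves by a number 14 percentage points higher from compound 2 to compound 3 (beyond the scatter) when 3,4-difluorophenyl replaces 3,4-dichlorophenyl on the sulfonyl sulfur, so fluorine in place of chlorine on this ring recovers only a modest part of the earlier loss and does not by itself restore the level of compound 1. The larger change is hydrogen in place of fluoro on an aromatic carbon, which gives a number 64 percentage points lower from compound 1 to compound 3 (beyond the scatter) and shows that a single fluoro on this ring can weigh far more in this assay than the exchange of both chlorines for fluorines. Nothing in hand explains either step.

The compounds shown carry only halogens on this phenyl, so they leave open how a nitrile, a methoxy group or a carboxylic acid on the same ring would compare. They also leave open whether the phenyl is needed at all, as a methyl group on the sulfonyl sulfur in its place would show, and which other fluoro groups of the 2,4,5-trifluorophenyl contribute to the read-out of compound 1.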